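This account rests on a few compounds, and the source may have more. Where it says the series, first, only, none or still open, it means among the compounds named here.

Of the compounds shown here, three sharing one core have been tested in a functional assay on HT-29 cells (Homo sapiens) for antiproliferative activity, read by MTT assay, with a stated time of 72 h; a higher number here means a weaker inhibitor, a lower number a stronger inhibitor. Compound 1 `CNC(=O)c1cc(Oc2ccc(NC(=O)c3cc4cccnc4n(-c4ccccc4)c3=O)cc2)ccn1` gives 250 nM in this assay. Compound 2 `CNC(=O)c1cc(Oc2ccc(NC(=O)c3cc4cccnc4n(-c4ccccc4F)c3=O)cc2)ccn1` gives 260 nM. Compound 3 `CCNC(=O)c1cc(Oc2ccc(NC(=O)c3cc4cccnc4n(-c4ccccc4)c3=O)cc2)ccn1` gives 220 nM, the lowest of the three numbers, yet all three lie within the scatter of one another, so none can be called more potent than the others.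

Compound 4 `CCNC(=O)c1cc(Oc2ccc(NC(=O)c3cc4cccnc4n(-c4ccc(Cl)cc4)c3=O)cc2)ccn1` is not yet measured. It differs from compound 3 in one place: chloro in place of hydrogen on an aromatic carbon.

Within the data shown here, two measured steps bear on this change. The step of a 1.0-fold higher number from compound 1 to compound 2 (0.02 log units; within the scatter) puts a halogen on the same phenyl ring and left the number essentially where it was. The step of a 1.1-fold lower number from compound 1 to compound 3 (0.06 log units; within the scatter) links compound 1 to compound 3 and also stayed within the scatter, so the fluoro result can reasonably be carried over to the ethyl series. Neither step gives any sign that a small halogen on this ring moves the number in either direction.

Compound 4 is therefore expected to show no change at the digits printed from compound 3 to compound 4 (within the scatter), no shift beyond the scatter. The estimate for compound 4 in this assay is 220 nM, with a range from 100 nM to 500 nM.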

Compound 4, half-maximal inhibitory concentration: 330 nM
The estimate for compound 4 lay 1.5-fold (0.18 log units) below the measured number, within the range that was stated.
By their numbers in this assay, from the lowest: compounds 3, 1, 2 and 4 (each within the scatter of the next).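

Chloro in place of hydrogen on the phenyl ring, para to a large group, gives in this assay a 1.5-fold higher number from compound 3 to compound 4 (0.18 log units; within the scatter), so this place on the ring carries a chloro group with no shift that can be told apart from the ordinary spread of repeated measurements. Until now the only halogen shown on this ring was the fluoro of compound 2, so the ring now carries a second halogen with the same outcome, and this time in a compound with an ethyl group on the amide rather than a methyl group. Nothing measured here offers an explanation for this result.

As far as these compounds go, only hydrogen, fluoro and chloro appear on this ring, so it stays open whether a methoxy group, an amine or a carboxylic acid at this place would move the number beyond the scatter. Also open, from the compounds shown here alone, are chains on the amide longer than ethyl, such as propyl, and how the 4-chlorophenyl group behaves when the amide carries a methyl group.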